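Swapping fluoro for bromo on a shared chromone core

The source may hold more compounds than are shown below. What is called first, only, known or untested is meant among the compounds shown, and "the series" means these compounds.

Measured so far:
compound 1 `CCO[C@H]1C[C@@H](c2coc3ccc(Br)cc3c2=O)N(c2ccccc2)O1` gives 21500 nM
compound 2 `COC(=O)[C@@]1(C)C[C@@H](c2coc3ccc(F)cc3c2=O)N(c2ccccc2)O1` gives 20300 nM
compound 3 `N#C[C@H]1C[C@@H](c2coc3ccc(Cl)cc3c2=O)N(c2ccccc2)O1` gives 40000 nM

All three were tested in a functional assay on A549 cells (Homo sapiens) for inhibition, read by sulforhodamine B assay, with a stated time of 48 h; a lower number here means a stronger inhibitor, a higher number a weaker inhibitor. Compound 2 has the lowest of the three numbers, but its gap to compound 1 and its gap to compound 3 both sit within the usual scatter, so no ordering among them can be claimed.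

The unmeasured compound 4 `COC(=O)[C@@]1(C)C[C@@H](c2coc3ccc(Br)cc3c2=O)N(c2ccccc2)O1` differs from compound 2 in one place: bromo in place of fluoro on an aromatic carbon. Fluoro leaves and bromo enters, on an aromatic carbon of a six-membered aromatic ring of carbon only, part of a fused system of two rings.

Going by the values given here, no pair of measured compounds isolates this change, so the step can only be judged from the values shown. Compound 1 also carries bromo, though it differs in other places too, and in this assay compound 1 gives 21500 nM; the values of compound 1 and compound 2 lie close together. The step of a 1.0-fold higher number from compound 2 to compound 4 (0.01 log units; within the scatter) is therefore expected to stay within the scatter, with no clear direction. Compound 4 is expected to give about 21000 nM, likely between 8000 nM and 55000 nM.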

Compound 4, half-maximal inhibitory concentration: 9900 nM
Compound 4: the middle estimate sits 2.1-fold (0.33 log units) above what was measured; the range from low to high includes it.
By their numbers in this assay, from the lowest: compound 4; then compounds 2, 1 and 3 (each within the scatter of the next).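

In this assay, bromo in place of fluoro gives a 2.1-fold lower number from compound 2 to compound 4 (0.31 log units; beyond the scatter). Going by these compounds alone, this is the first comparison in which only one group differs, and it shows that the group on this aromatic carbon can move the number by a modest amount beyond the scatter. Within the data shown here, the single pair gives a direction for these two halogens only and sets no wider trend, and nothing measured here offers an explanation for the step.

On these data alone, what a methoxy group or an amine would do on this same aromatic carbon stays open, as does a chloro there with the rest of compound 2 kept. Also open, as far as these compounds go, is whether the same swap gives a similar step when the other parts of the molecule differ, as they do in compound 1 and compound 3.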